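The source may report more compounds than this note shows. Statements on the series, on what has been measured and on what is new or still open speak of the compounds shown alone.

Measured in a functional assay on the whole organism with Mus musculus as the target; on this read-out lower numbers stand for an effect already at smaller amounts and higher numbers for an effect only at larger amounts of compound:

compound 1, `O=c1oc2cccnc2n1CN1CCN(c2cccc(C(F)(F)F)c2)CC1`: 3.6 mg/kg
compound 2, `O=c1oc2cccnc2n1CN1CCN(c2cccc(Cl)c2)CC1`: 10.5 mg/kg
compound 3, `CCN(CC)CCn1c(=O)oc2cccnc21`: > 25 mg/kg

For compound 3 the figure is a limit of this assay, not a number (the limit of > 25 mg/kg in this assay, at which 1 of the 3 values shown sits). Of the two numbers, compound 2 holds the higher one; the nearest is compound 1, with a 2.9-fold higher number from compound 1 to compound 2 (0.46 log units; beyond the scatter). Compound 4, `O=c1oc2cccnc2n1CN1CCN(c2ccc(F)cc2)CC1`, is not yet measured in this assay. It differs from compound 2 by 4-fluorophenyl in place of 3-chlorophenyl on an amine nitrogen in a ring. For the measured compounds named here, the only measured step that bears on this is the exchange of one aryl substituent for another from compound 1 to compound 2, a modest step beyond the scatter. A change of similar size in either direction, or none beyond the scatter, is therefore expected. The estimate for compound 4 is 12 mg/kg, range 5 mg/kg to 25 mg/kg, which is expected to mean a 1.1-fold higher number from compound 2 to compound 4 (0.06 log units; within the scatter).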

Compound 4, dose for half-maximal effect: 3.5 mg/kg
Beside the measured number, compound 4's estimate is 3.4-fold (0.54 log units) above it, and the stated range ends above it.
By their numbers in this assay, from the lowest: compounds 4 and 1 (each within the scatter of the next); then compound 2. At a limit, above all of these: compound 3.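

In this assay the exchange of 3-chlorophenyl for 4-fluorophenyl on the amine nitrogen in a ring gives a 3.0-fold lower number from compound 2 to compound 4 (0.48 log units; beyond the scatter), so a single aryl exchange at this position can move the number beyond the scatter without trifluoromethyl. Compound 4 stands within the scatter of compound 1, so a trifluoromethyl group is not required on the aryl ring for the lower numbers in this series. Nothing measured here gives a cause for this step. The step changes the halogen and its ring position together, leaving their separate contributions open. A 4-chlorophenyl or 3-fluorophenyl group would separate the two.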